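Chlorophenyl rearrangement in the tetrabromo series: compound 4 outlook

A few compounds are considered here, and "the series" means these few. Any claim that something is new, unique, unknown or untested is made for them only; others in the source may bear on it.

Working notes on three measured compounds and one pending. Compound 1 `OC(CCn1nc2c(Br)c(Br)c(Br)c(Br)c2n1)c1ccccc1` in a functional assay on MCF7 cells (Homo sapiens) for antiproliferative activity, read by MTT assay, with a stated time of 24 h, tested at 100 uM (on this read-out higher numbers stand for a weaker effect at the one concentration tested and lower numbers for a stronger effect), gives 13%. Compound 2 `C[C@@H](O)CCn1nc2c(Br)c(Br)c(Br)c(Br)c2n1` in this assay gives 18%. Compound 3 `OC(CCn1nc2c(Br)c(Br)c(Br)c(Br)c2n1)c1cccc(Cl)c1` in this assay gives 0%, the lowest of the three numbers; compound 1 is nearest, higher beyond the scatter, and compound 2 is furthest, also higher beyond the scatter. Within the data shown here, the one single-change step recorded is chloro in place of hydrogen on an aromatic carbon, which gave a number 13 percentage points lower from compound 1 to compound 3 (beyond the scatter), a modest move.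

Compound 4 `OC(CCn1nc2c(Br)c(Br)c(Br)c(Br)c2n1)c1ccc(Cl)cc1` differs from compound 3 by 4-chlorophenyl in place of 3-chlorophenyl on a saturated chain carbon bound to an oxygen on a saturated carbon and a saturated chain carbon. Among the measured compounds shown here, no measured pair in this set moves the chloro between ring positions, so the step from compound 1 to compound 3 bears only indirectly: it shows that the chloro itself is tolerated and read as a stronger effect. For the measured compounds named here, with the same atoms joined differently and no precedent for the rearrangement, no step beyond the scatter is expected in this assay; since compound 3 already sits at the floor of the read-out, any movement can only be upward. Compound 4 is therefore estimated at 6%, within 0% to 25%, which means an expected step of a number 6 percentage points higher from compound 3 to compound 4 (within the scatter).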

Compound 4, a percentage reported as activity, at one concentration (the size of the read-out at that concentration, not a potency): 0%
Estimate against measurement, compound 4: 6 percentage points above; the range from low to high includes it.
By their numbers in this assay, from the lowest: compounds 3 and 4 (each within the scatter of the next); then compounds 1 and 2 (each within the scatter of the next).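

In this assay, among these compounds, the rearrangement of the chloro is now seen directly for the first time: 4-chlorophenyl in place of 3-chlorophenyl, on the saturated chain carbon that carries the oxygen, gives no change at the digits printed from compound 3 to compound 4 (within the scatter). The chloro step from the plain phenyl now stands twice, with a number 13 percentage points lower from compound 1 to compound 4 (beyond the scatter) alongside a number 13 percentage points lower from compound 1 to compound 3 (beyond the scatter), so the lower number holds for both the 3-chlorophenyl and the 4-chlorophenyl groups in these two compounds. Nothing available explains why the two chlorophenyl groups read alike.

Compound 3 and compound 4 both sit at the floor of the read-out at a single concentration, so any difference in potency between them stays hidden and would need a full concentration series to show. Also open, going by these compounds, is whether another group at the same ring position, such as a methoxy group, an amine or a carboxylic acid, would keep the number of compound 4 or return it toward that of compound 1, and whether either chlorophenyl group would behave the same way on a longer chain.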